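Semicarbazone linker variants on a shared quinoline-ether core

The compounds below may be only part of what the source reports. "The series", "measured", "known", "first", "only" and "open" are said of these compounds alone.

Measured so far in a functional assay on HT-29 cells (Homo sapiens) for cytotoxicity, read by MTT assay, with a stated time of 72 h; on this read-out higher numbers stand for weaker inhibition and lower numbers for stronger inhibition:
compound 1 `COc1ccc(/C=N/NC(=O)Nc2ccc(Oc3ccnc4cc(OCCCN5CCCCC5)c(OC)cc34)c(F)c2)cc1` gives 590 nM
compound 2 `COc1cc2c(Oc3ccc(NC(=O)N/N=C/c4ccncc4)cc3F)ccnc2cc1OCCCN1CCCCC1` gives 940 nM
compound 3 `COc1cc2c(Oc3ccc(NC(=O)N/N=C/c4cccs4)cc3F)ccnc2cc1OCCCN1CCCCC1` gives 770 nM

Compound 3 sits within the scatter of both neighbours: a 1.3-fold higher number from compound 1 to compound 3 (0.12 log units; within the scatter) and a 1.2-fold lower number from compound 2 to compound 3 (0.09 log units; within the scatter), so the three numbers cannot be told apart.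

Compound 4 `COc1cc2c(Oc3ccc(/C=N/NC(=O)Nc4ccccc4)cc3F)ccnc2cc1OCCCN1CCCCC1` differs from compound 3 by a group of 12 heavy atoms (8 carbon, 3 nitrogen, 1 oxygen; one six-membered aromatic ring of carbon only) in place of a group of 11 heavy atoms (6 carbon, 3 nitrogen, 1 oxygen, 1 sulfur; one five-membered aromatic ring with 1 hetero atom), on an aromatic carbon. The change therefore touches the whole linker-plus-aryl portion, not only the terminal ring.

The steps measured so far – a 1.6-fold higher number from compound 1 to compound 2 (0.20 log units; within the scatter), a 1.3-fold higher number from compound 1 to compound 3 (0.12 log units; within the scatter), a 1.2-fold lower number from compound 2 to compound 3 (0.09 log units; within the scatter) – all exchange only the ring on the carbon with a double bond to nitrogen, and none moved this assay beyond the scatter. Among the measured compounds shown here, no measured step changes the arrangement of the linker itself, so the data give no direction for the step from compound 3 to compound 4; a wider range is appropriate.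

Compound 4 is expected to stay in the same region, with a step of a 1.2-fold higher number from compound 3 to compound 4 (0.07 log units; within the scatter) and an estimate of 900 nM (range 300 nM to 3000 nM).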

Compound 4, half-maximal inhibitory concentration: 190 nM
For compound 4 the middle estimate is 4.7-fold (0.68 log units) above the measured one; measured number below the stated range.
By their numbers in this assay, from the lowest: compound 4; then compounds 1, 3 and 2 (each within the scatter of the next).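

Moving from the earlier linker arrangement to that of compound 4 produces the first steps beyond the scatter in this assay (a 4.1-fold lower number from compound 3 to compound 4 (0.61 log units; beyond the scatter); a 4.9-fold lower number from compound 2 to compound 4 (0.69 log units; beyond the scatter)). The linker-plus-aryl portion on the aromatic carbon para to a large group therefore affects this read-out, whereas the ring exchanges among compound 1, compound 2 and compound 3 all stayed within the scatter. No measurement in hand gives a cause for this difference.

Compound 4 changes the linker arrangement and the terminal ring together, so the contribution of each remains unresolved. On these data alone, it is also open whether the arrangement of compound 4 keeps its number in this assay with a 4-chlorophenyl or 4-trifluoromethylphenyl group as the terminal ring.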